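The source may hold more compounds than are shown below. What is called first, only, known or untested is meant among the compounds shown, and "the series" means these compounds.

Measured compounds:
Compound 1 `CC(C)=CCC[C@@](C)(/C=C/c1ccccc1)/C=C/c1ccc(O)cc1` — in a functional assay on HepG2 cells (Homo sapiens) for cytotoxicity, with a stated time of 72 h (on this read-out lower numbers stand for an effect already at smaller amounts and higher numbers for an effect only at larger amounts of compound), compound 1 gives > 52000 nM, which is a limit of the assay and not a number.
Compound 2 `CC(C)=CCC[C@](C)(/C=C/c1ccc(O)cc1)/C=C/c1cccc(Cl)c1` — in this assay compound 2 gives > 52000 nM, again only a limit.
Compound 3 `C=C[C@@](C)(/C=C/c1ccc(-c2ccc(Cl)cc2)cc1)CCC=C(C)C` — in this assay compound 3 gives > 52000 nM, also a limit.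

The change from compound 1 to compound 2 is chloro in place of hydrogen on an aromatic carbon; it yields a step that the two limits leave unreadable from compound 1 to compound 2. With a limit on both sides, the size of this step stays unreadable. How the core of compound 1 and the core of compound 3 differ is not broken down here.

Compound 4 `C=C[C@@](C)(/C=C/c1ccc(-c2ccc(Cl)c(Cl)c2)cc1)CCC=C(C)C` is not yet measured. It arises from compound 3 by chloro in place of hydrogen on an aromatic carbon. This is the same kind of change as that from compound 1 to compound 2, not the same: in compound 4 the entering chloro sits ortho to a chloro group (1 heavy atom) and meta to a large group, whereas in compound 2 it sits meta to a large group only.

For compound 4 the step that the limit leaves unreadable from compound 3 to compound 4 is expected, resting on (the limit of > 52000 nM in this assay, at which 3 of the 3 values shown sit). Compound 4 is therefore estimated at 90000 nM, most probably reported once more as a limit only.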

Compound 4, half-maximal effective concentration: > 52000 nM
Compound 4 ended at the assay's limit (the forecaster's own chance of this, stated with the estimate: 80%); the middle value is on the limit's open side.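

Among the compounds shown here, with compound 3 and compound 4 both reported only as limits in this assay, the change from 4-chlorophenyl to 3,4-dichlorophenyl yields no step that can be read. The compounds shown leave open whether any of these structures has a measurable effect on these cells, and what size a chloro step has, as every value is a limit: the limit of > 52000 nM in this assay, at which 4 of the 4 values shown sit.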